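This account rests on a few compounds, and the source may have more. Where it says the series, first, only, none or still open, it means among the compounds named here.

Measured compounds:
Compound 1, `Cc1cc(C#N)cc(C)c1Oc1ccnc(SCC(=O)Nc2ccc(C#N)cc2)n1`: > 300000 nM
Compound 2, `Cc1cc(C#N)cc(C)c1Oc1ccnc(S(=O)(=O)CC(=O)Nc2ccccc2)n1`: 29300 nM

In an ADME assay on MT4 cells (Homo sapiens) for cytotoxicity, read by MTT assay, with a stated time of 4 days (a higher number here means that more compound is tolerated, a lower number that less compound is tolerated), compound 2 gives 29300 nM. Compound 1 sits at the limit of > 300000 nM in this assay, at which 1 of the 2 values shown sits, which is a limit of the assay rather than a number. Among the two values shown, compound 2 therefore holds the only actual number; the other value is a limit. Compound 3, `Cc1cccc(NC(=O)CS(=O)(=O)c2nccc(Oc3c(C)cc(C#N)cc3C)n2)c1`, has not yet been measured in this assay. It differs from compound 2 in a single place: methyl in place of hydrogen on an aromatic carbon. No step between two measured compounds is shown here, so there is no measured change of this kind to lean on. A single methyl entering on that ring is a small change, and the step of a 1.2-fold lower number from compound 2 to compound 3 (0.07 log units; within the scatter) is expected to stay within the usual scatter of repeated measurements, in no clear direction. Compound 3 is accordingly estimated at 25000 nM, with a likely range from 8000 nM to 80000 nM.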

Compound 3, half-maximal cytotoxic concentration: 25700 nM
Compound 3: the middle estimate sits 1.0-fold (0.01 log units) below what was measured; measured number inside the range.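

In this assay, among these compounds, the change from phenyl to 3-methylphenyl gives a 1.1-fold lower number from compound 2 to compound 3 (0.06 log units; within the scatter) and so provides the first measured step between two compounds that differ in one place. At this position on the ring, then, adding one methyl does not change the tolerated concentration by more than repeated measurements normally would. Nothing measured here offers a reason for this result.

From the compounds shown here alone, one methyl at one position says little about other groups: whether an amine, a carboxylic acid or a longer chain at the same place would move the number beyond the scatter remains open. Going by these compounds, it also remains open whether a methyl elsewhere on this ring would behave in the same way, or whether this small step would hold on a different core.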